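Swapping a Naphthyl for an Indolyl on a Weak Inhibitor

A few compounds are considered here, and "the series" means these few. Any claim that something is new, unique, unknown or untested is made for them only; others in the source may bear on it.

Measured so far, in a functional assay on aorta (strain Wistar) for inhibition, with Thoracic aorta (Rattus norvegicus) as the target; on this read-out higher numbers stand for weaker inhibition and lower numbers for stronger inhibition:
- compound 1, `CCOc1nc(-c2cc3ccccc3o2)cc(-c2ccc3ccccc3c2)c1C#N`, gives 423000 nM
- compound 2, `CCOc1nc(-c2cc3ccccc3o2)cc(-c2cc(OC)c(OC)c(OC)c2)c1C#N`, gives 365000 nM

Going by the values given here, of these two numbers, the one for compound 1 stands at the top, though its gap to compound 2 lies within the usual scatter of repeated measurements, so the two compounds cannot be told apart. Compound 3, `CCOc1nc(-c2cc3ccccc3o2)cc(-c2cn(C)c3ccccc23)c1C#N`, has not yet been measured in this assay. It differs from compound 1 in one place: 1-methyl-1H-indol-3-yl in place of naphthalen-2-yl on an aromatic carbon. Nothing measured here shows how such a swap moves the read-out, so the step of a 1.1-fold lower number from compound 1 to compound 3 (0.02 log units; within the scatter) is expected to stay within the scatter. Compound 3 is therefore estimated at 400000 nM, between 150000 nM and 1000000 nM.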

Compound 3, half-maximal inhibitory concentration: 327000 nM
The estimate for compound 3 lay 1.2-fold (0.09 log units) above the measured number; the range from low to high includes it.
By their numbers in this assay, from the lowest: compounds 3, 2 and 1 (each within the scatter of the next).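

In this assay, putting 1-methyl-1H-indol-3-yl in place of naphthalen-2-yl, on the carbon ortho to the cyano group, gives a 1.3-fold lower number from compound 1 to compound 3 (0.11 log units; within the scatter), so the two compounds cannot be told apart. At this position, then, a ring with one hetero atom and one hydrogen-bond acceptor reads the same as an all-carbon pair of rings of equal heavy-atom count. Nothing measured here bears on why this is so.

All the groups shown at this position are aromatic rings. Going by these compounds, whether a carboxylic acid or an amine there would shift the number remains open.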